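The source may hold more compounds than are shown below. What is called first, only, known or untested is meant among the compounds shown, and "the series" means these compounds.

Measured in an assay on isolated protein for inhibition of cathepsin S (Homo sapiens), read by fluorescence, with a stated time of 20 min; on this read-out higher numbers stand for weaker inhibition and lower numbers for stronger inhibition:
- compound 1 `N#CC1(NC(=O)[C@@H]2C[C@@H](S(=O)(=O)c3ccccc3)C[C@H]2C(=O)N2CCOCC2)CC1`: 0.7 nM
- compound 2 `N#CC1(NC(=O)[C@@H]2C[C@@H](S(=O)(=O)c3ccccc3)C[C@H]2C(=O)N2CCCCC2)CC1`: 0.8 nM
- compound 3 `N#CC1(NC(=O)[C@@H]2C[C@@H](S(=O)(=O)c3ccccc3)C[C@H]2C(=O)N2CCC(O)CC2)CC1`: 1 nM

Compound 1 gives the lowest of the three numbers, but its neighbours sit close: the step of a 1.1-fold higher number from compound 1 to compound 2 (0.06 log units; within the scatter) and the step of a 1.4-fold higher number from compound 1 to compound 3 (0.15 log units; within the scatter) both stay within the scatter, as does the step of a 1.3-fold higher number from compound 2 to compound 3 (0.10 log units; within the scatter). On the numbers shown, the three compounds cannot be told apart in this assay.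

All three measured changes replace one group on the same carbonyl carbon with another saturated six-membered ring group, and none moves the number beyond the scatter. Compound 4 `CN(C)C(=O)[C@@H]1C[C@H](S(=O)(=O)c2ccccc2)C[C@H]1C(=O)NC1(C#N)CC1` makes a change at the same place: dimethylamino in place of morpholin-4-yl on a carbonyl carbon. Among the measured compounds shown here, no measured step swaps a ring group for an open-chain group here, so the bearing of the measured steps is indirect: they show only that this position has so far tolerated exchange without a shift beyond the scatter.

The expectation for compound 4 in this assay is therefore a step of a 1.4-fold higher number from compound 1 to compound 4 (0.15 log units; within the scatter), that is, no change beyond the scatter. Compound 4 is estimated at 1 nM, with a range from 0.4 nM to 3 nM.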

Compound 4, half-maximal inhibitory concentration: 6 nM
For compound 4 the middle estimate is 6.0-fold (0.78 log units) below the measured one, and the stated range ends below it.
By their numbers in this assay, from the lowest: compounds 1, 2 and 3 (each within the scatter of the next); then compound 4.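

In this assay the position on the carbonyl carbon proves not to be indifferent to every exchange, since an 8.6-fold higher number from compound 1 to compound 4 (0.93 log units; beyond the scatter) and a 7.5-fold higher number from compound 2 to compound 4 (0.88 log units; beyond the scatter) and a 6.0-fold higher number from compound 3 to compound 4 (0.78 log units; beyond the scatter) point the same way, towards weaker inhibition, each modest but beyond the scatter. Among the compounds shown here, the tolerance seen among morpholin-4-yl, piperidin-1-yl and 4-hydroxypiperidin-1-yl therefore does not reach dimethylamino, the only group here without a ring and the one with the fewest heavy atoms, while the ring oxygen of morpholin-4-yl and the hydroxy of 4-hydroxypiperidin-1-yl still give no separation among the ring groups. Nothing at hand accounts for the shift.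

The compounds shown do not separate loss of the ring from loss of heavy atoms: pyrrolidin-1-yl and azetidin-1-yl keep a ring with fewer atoms, and diethylamino stays open-chain with more. Also open, from the compounds shown here alone, is how far the ring tolerance extends, for example to 4-aminopiperidin-1-yl or to a piperidine ring carrying a carboxylic acid.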